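Ring-nitrogen substituents: notes toward compound 4

The source may hold more compounds than are shown below. What is called first, only, known or untested is meant among the compounds shown, and "the series" means these compounds.

Measured so far:
Compound 1, `Cc1cccc2sc(NC(=O)CCN3CCN(C(C)(C)C)CC3)nc12`, gives 200 nM in an assay on membranes from liver for displacement of a labelled ligand from Sigma intracellular receptor 2 (Rattus norvegicus), read by scintillation counting, with a stated time of 120 min; a lower number here means a stronger inhibitor, a higher number a weaker inhibitor.
Compound 2, `Cc1cccc2sc(NC(=O)CCN3CCN(C4CCCCC4)CC3)nc12`, gives 233 nM in this assay.
Compound 3, `Cc1cccc2sc(NC(=O)CCN3CCN(C4CCN(C)CC4)CC3)nc12`, gives 3600 nM in this assay.

Compound 1 stands at the lowest number of the three. Its nearest neighbour is compound 2, with a 1.2-fold higher number from compound 1 to compound 2 (0.07 log units; within the scatter), a gap within the scatter, so no order between them is claimed. Compound 3 is far from both: an 18-fold higher number from compound 1 to compound 3 (1.26 log units; beyond the scatter) and a 15-fold higher number from compound 2 to compound 3 (1.19 log units; beyond the scatter).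

Compound 4, `Cc1cccc2sc(NC(=O)CCN3CCN(CCN(C(C)C)C(C)C)CC3)nc12`, differs from compound 1 in one place: 2-(diisopropylamino)ethyl in place of tert-butyl on an amine nitrogen in a ring. The entering group, like the 1-methylpiperidin-4-yl of compound 3, carries one hydrogen-bond acceptor where tert-butyl carries none, so the step that bears most on it is an 18-fold higher number from compound 1 to compound 3 (1.26 log units; beyond the scatter). The step of a 1.2-fold higher number from compound 1 to compound 2 (0.07 log units; within the scatter) shows that exchanging tert-butyl for cyclohexyl changes little. Going by the values given here, the open-chain nitrogen of compound 4 has no direct precedent, so the weakening seen in compound 3 is taken as an outer bound rather than a forecast. A step upward beyond the scatter, smaller than that to compound 3, is expected: a 4.5-fold higher number from compound 1 to compound 4 (0.65 log units; beyond the scatter). For compound 4 the estimate is 900 nM, with a range from 250 nM to 3500 nM.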

Compound 4, inhibition constant: 121 nM
Compound 4: middle estimate off by 7.4-fold (0.87 log units), on the high side; measured number below the stated range.
By their numbers in this assay, from the lowest: compounds 4, 1 and 2 (each within the scatter of the next); then compound 3.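

In this assay the ring nitrogen accepts the open-chain 2-(diisopropylamino)ethyl group with no separation from the smaller groups, since a 1.7-fold lower number from compound 1 to compound 4 (0.22 log units; within the scatter) and a 1.9-fold lower number from compound 2 to compound 4 (0.28 log units; within the scatter) both lie within the scatter. A hydrogen-bond acceptor in the entering group therefore does not by itself go with weakening, and a 30-fold lower number from compound 3 to compound 4 (1.47 log units; beyond the scatter) ties the high number of compound 3 to the 1-methylpiperidin-4-yl group rather than to any nitrogen-bearing substituent at this position. No measurement at hand accounts for the gap between these two nitrogen-bearing groups.

Still open, as far as these compounds go, is which part of 1-methylpiperidin-4-yl goes with the weakening, a question that a piperidin-4-yl group with a free amine hydrogen or a tetrahydropyran-4-yl group would address. Also open, from the compounds shown here alone, is how far the chain tolerates change, for example a propyl linker to the diisopropylamino group or a smaller dimethylamino end.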